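Benzoyl-pyrrole boronate series: cytotoxicity working notes

The compounds below may be only part of what the source reports. "The series", "measured", "known", "first", "only" and "open" are said of these compounds alone.

Measured so far:
compound 1 `O=C(c1ccc(F)cc1)c1ccn(-c2ccc3c(c2)B(O)OC3)c1`: > 10 ug/mL
compound 2 `O=C(c1cccc(Cl)c1)c1ccn(-c2ccc3c(c2)B(O)OC3)c1`: > 10 ug/mL
compound 3 `Cc1ccccc1C(=O)c1ccn(-c2ccc3c(c2)B(O)OC3)c1`: not yet measured

In an ADME assay on L929 cells (Mus musculus) for cytotoxicity, read by resazurin assay, with a stated time of 72 h (on this read-out lower numbers stand for stronger inhibition and higher numbers for weaker inhibition), compound 1 gives only an assay limit, > 10 ug/mL, and not a number. In this assay compound 2 likewise gives only an assay limit, > 10 ug/mL. The step that the two limits leave unreadable from compound 1 to compound 2 is therefore unreadable, as both readings sit at the limit of > 10 ug/mL in this assay, at which 2 of the 2 values shown sit. Compound 2 thus stands at the limit of this assay, with no numeric position on the scale.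

Compound 3 differs from compound 2 by 2-methylphenyl in place of 3-chlorophenyl on a carbonyl carbon. Going by the values given here, the only measured step, a step that the two limits leave unreadable from compound 1 to compound 2, bears on a change at the same carbonyl carbon but gives no readable size, so no direction or magnitude beyond the scatter can be derived for compound 3 in this assay. Compound 3 is expected to come out at about 15 ug/mL, in the range 5 ug/mL to 40 ug/mL, and is most likely to be reported again as a limit rather than a number. The step that the limit leaves unreadable from compound 2 to compound 3 is the expectation implied by this estimate.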

Compound 3, half-maximal inhibitory concentration: > 10 ug/mL
Compound 3: only a limit was reported; the forecaster's own chance of this, stated with the estimate: 80%; the middle value does not contradict the limit.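

In this assay compound 3 gives > 10 ug/mL as a limit again, not a number. The steps from compound 2 to compound 3 and from compound 1 to compound 3 therefore cannot be read: the limit of > 10 ug/mL in this assay, at which 3 of the 3 values shown sit. The compounds shown leave open where compound 1, compound 2 and compound 3 lie on the scale of this assay and whether the changes on the carbonyl carbon shift the reading at all.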